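The source may hold more compounds than are shown below. What is called first, only, known or untested is meant among the compounds shown, and "the series" means these compounds.

Two compounds of the series carry a result in a functional assay on LoVo cells (Homo sapiens) for inhibition, read by MTT assay, with a stated time of 72 h; on this read-out lower numbers stand for stronger inhibition and higher numbers for weaker inhibition. Compound 1 `Cc1noc(C)c1-c1cnc(N)c(Oc2ccc(C(=O)Nc3ccccc3Cl)cc2)n1` reaches only the assay limit, giving > 100000 nM in this assay. In this assay, among the compounds with values here, compound 2 `Cc1noc(C)c1-c1cnc(N)c(Sc2ccc(C(=O)Nc3ccc(Cl)cc3)cc2)n1` gives 49200 nM, the only number so far. The other value shown is a limit (the limit of > 100000 nM in this assay, at which 1 of the 2 values shown sits). Compound 3 `Cn1cc(-c2cnc(N)c(Sc3ccc(C(=O)Nc4ccc(Cl)cc4)cc3)n2)cn1` is unmeasured; it differs from compound 2 by 1-methyl-1H-pyrazol-4-yl in place of 3,5-dimethyl-1,2-oxazol-4-yl on an aromatic carbon. Within the data shown here, no measured pair probes this change, so the expected step of a 1.2-fold lower number from compound 2 to compound 3 (0.09 log units; within the scatter) is none beyond the scatter. Compound 3 is estimated at 40000 nM, between 10000 nM and 150000 nM, with a fair chance of a limit only.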

Compound 3, half-maximal inhibitory concentration: > 100000 nM
Compound 3 was reported as a limit; the forecaster's own chance of this, stated with the estimate: 25%; at least 2.5-fold (0.39 log units) between middle value and limit.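

In this assay compound 3 reaches only a limit, > 100000 nM, which gives this position its first probe. The change of 1-methyl-1H-pyrazol-4-yl in place of 3,5-dimethyl-1,2-oxazol-4-yl shows no gain, with an at least 2.0-fold higher number from compound 2 to compound 3 (0.30 log units; that floor lies within the scatter), and that step is a floor rather than a size. Compound 2 remains the only compound with a number, and the other values share one limit: the limit of > 100000 nM in this assay, at which 2 of the 3 values shown sit.

Going by these compounds, how far compound 3 actually lies from compound 2 stays open. Also open, on these data alone, is whether a pyridine ring, a morpholine or a primary amine at this position would give a number in this assay.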